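The source may report more compounds than this note shows. Statements on the series, on what has been measured and on what is new or still open speak of the compounds shown alone.

Compound 1 `CCCc1nc(C)c2c(CC)nnc(SC)n12` in a functional assay for inhibition, with Homo sapiens as the target (a lower number here means a stronger inhibitor, a higher number a weaker inhibitor), gives > 48000 nM.
Compound 2 `CCCc1nc(C)c2c(C)nnc(O)n12` in this assay gives 14000 nM.
Compound 3 `CCc1nnc(O)n2c(CC)nc(C)c12` in this assay gives 24000 nM.

Of the compounds shown here, three on a shared core have been measured. For compound 1 the result is a limit of this assay rather than a number (the limit of > 48000 nM in this assay, at which 1 of the 3 values shown sits). Among the two numbers that are known, compound 3 has the higher one, but its nearest neighbour is compound 2, and the gap between them lies within the usual scatter of repeated measurements, so no order between compound 2 and compound 3 can be read from them. Within the data shown here, no pair of measured compounds differs in a single place, so no measured step on this core is available.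

Compound 4 `CCCc1nc(C)c2c(CC)nnc(O)n12` has not yet been measured. It differs from compound 3 in one place: methyl in place of hydrogen on a saturated chain carbon, two bonds along the chain from an aromatic carbon, so that an ethyl chain becomes a propyl chain. Among the measured compounds shown here, with no measured step of this kind to lean on, the expected change in this assay is small and of no clear direction, nothing beyond the scatter. The step from compound 3 to compound 4 is therefore estimated at a 1.4-fold lower number from compound 3 to compound 4 (0.15 log units; within the scatter). On that basis compound 4 is expected to give about 17000 nM, most likely between 6000 nM and 45000 nM.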

Compound 4, half-maximal inhibitory concentration: 15600 nM
Compound 4: the middle estimate sits 1.1-fold (0.04 log units) above what was measured; the measured number falls inside the stated range.
By their numbers in this assay, from the lowest: compounds 2, 4 and 3 (each within the scatter of the next). At a limit, above all of these: compound 1.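

Neither chain extension gives a readable difference in this assay: an ethyl chain becoming a propyl chain gives a 1.5-fold lower number from compound 3 to compound 4 (0.19 log units; within the scatter), and methyl becoming ethyl on the other chain gives a 1.1-fold higher number from compound 2 to compound 4 (0.05 log units; within the scatter), so at this size of change these chains show no direction of effect. Among these compounds, the one step on this core that lies beyond the scatter comes with hydroxy in place of methylsulfanyl on an aromatic carbon, an at least 3.0-fold lower number from compound 1 to compound 4 (0.48 log units; beyond the scatter). The size of that step is only a minimum, as compound 1 has a limit and not a number: the limit of > 48000 nM in this assay, at which 1 of the 4 values shown sits.

On these data alone, it remains open whether a longer chain such as butyl, or a small ring such as cyclopropyl, on either chain carbon would give a difference beyond the scatter. Also open, as far as these compounds go, is how an amine or a methoxy group in place of the hydroxy would read, and so whether the lower number depends on the hydroxy itself or only on the loss of the methylsulfanyl.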